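A difluoromethoxy swap on a compound at the assay limit

A few compounds are considered here, and "the series" means these few. Any claim that something is new, unique, unknown or untested is made for them only; others in the source may bear on it.

Compound 1 `COc1cc(CNc2ncnc3c2ncn3[C@@H]2O[C@H](CO)[C@@H](O)[C@H]2O)cc(OC)c1` gives "not determined" (no result reported) as its entry
Compound 2 `Cc1cccc(CNc2ncnc3c2ncn3[C@@H]2O[C@H](CO)[C@@H](O)[C@H]2O)c1O` gives > 166000 nM as its entry, which is a limit

In a functional assay on HOS cells (Homo sapiens) for antiproliferative activity, with a stated time of 72 h (a lower number here means a stronger inhibitor, a higher number a weaker inhibitor), compound 2 gives > 166000 nM as its reading. This is a limit and not a number. Going by the values given here, the whole measured picture therefore comes down to the limit of > 166000 nM in this assay, at which 1 of the 2 values shown sits, as the only reading. Compound 1 has no result to compare with.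

The next compound, compound 3 `OC[C@H]1O[C@@H](n2cnc3c(NCc4ccccc4OC(F)F)ncnc32)[C@H](O)[C@@H]1O`, keeps the shared core and differs from compound 2 as follows: 2-(difluoromethoxy)phenyl in place of 2-hydroxy-3-methylphenyl on a saturated chain carbon bound to a nitrogen on an aromatic ring. In words, it carries 2-(difluoromethoxy)phenyl in place of 2-hydroxy-3-methylphenyl on a saturated chain carbon bound to a nitrogen on an aromatic ring.

Among the compounds with values here, no measured pair shows what a change at this place does, so the expected size of the step is a judgement. With compound 2 at > 166000 nM in this assay, only a stronger result could appear as a number, so a moderate gain is expected, and another limit remains quite possible. The estimated change is an at least 2.7-fold lower number from compound 2 to compound 3 (0.44 log units; beyond the scatter) in this measurement. For compound 3 the estimate is 60000 nM, with an expected range from 10000 nM to 166000 nM.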

Compound 3, half-maximal inhibitory concentration: > 166000 nM
Compound 3: a limit, no number (the forecaster's own chance of this, stated with the estimate: 50%); middle value at least 2.7-fold (0.44 log units) from the limit.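

Compound 3 ends at a limit, as compound 2 does, so no step between these two compounds can be read, and neither entry is a number: the limit of > 166000 nM in this assay, at which 2 of the 3 values shown sit.

The compounds shown leave open whether any group at this place on the shared core would give an actual number in this assay.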